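Hydroxymethyl added to the aryl ring of compound 2

This account rests on a few compounds, and the source may have more. Where it says the series, first, only, none or still open, it means among the compounds named here.

Measured so far:
Compound 1 `CN(C)c1ccc(-c2nc3c(s2)C(O)CNC3)cc1` gives 170 nM in a functional assay on MDA-MB-361 cells (Homo sapiens) for cytotoxicity, read by sulforhodamine B assay, with a stated time of 2 days; on this read-out higher numbers stand for weaker inhibition and lower numbers for stronger inhibition.
Compound 2 `OC1CNCc2nc(-c3ccc(N4CCCC4)cc3)sc21` gives 140 nM in this assay.
Compound 3 `OC1CCCc2nc(-c3ccc(N4CCCC4)cc3)sc21` gives 200 nM in this assay.

Compound 2 carries the lowest of the three numbers, but its gaps to compound 1 and to compound 3 are both within the scatter, so no ranking among the three can be drawn. Among the measured compounds shown here, the one single-point step available, a 1.2-fold lower number from compound 1 to compound 2 (0.08 log units; within the scatter), exchanges the amine on the aryl ring and is itself within the scatter.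

Compound 4 `OCc1cc(N2CCCC2)ccc1-c1nc2c(s1)C(O)CNC2` is not yet measured. It differs from compound 2 by hydroxymethyl in place of hydrogen on an aromatic carbon. For the measured compounds named here, no measured step touches this kind of change: the step from compound 1 to compound 2 concerns a different group on the same ring, and compound 3 differs from compound 2 in the core. There is thus no measured basis for a direction, and the expectation in this assay is a step of no more than the usual scatter, in either direction. Compound 4 is therefore expected to give about 200 nM, within 60 nM to 700 nM, which means an expected step of a 1.4-fold higher number from compound 2 to compound 4 (0.15 log units; within the scatter).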

Compound 4, half-maximal inhibitory concentration: 20 nM
Estimate against measurement, compound 4: 10-fold (1.00 log units) above, and the stated range ends above it.
By their numbers in this assay, from the lowest: compound 4; then compounds 2, 1 and 3 (each within the scatter of the next).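

In this assay, among the compounds shown here, hydroxymethyl in place of hydrogen on this aromatic carbon, ortho to a large group and meta to the pyrrolidin-1-yl group, gives a 7.0-fold lower number from compound 2 to compound 4 (0.85 log units; beyond the scatter), the only step beyond the scatter. The earlier compounds showed no change that separated one value from another, so this carbon of the aryl ring is the one place shown where a single substitution moves the number. No measurement bearing on the origin of this step is available.

As far as these compounds go, it remains open whether the step needs the hydroxyl or only the added carbon; a methyl, methoxymethyl or aminomethyl group on the same carbon would separate these cases. Also open, from the compounds shown here alone, is whether hydroxymethyl gives a similar step with the core of compound 3 or the dimethylamino group of compound 1.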